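The source may report more compounds than this note shows. Statements on the series, on what has been measured and on what is new or still open speak of the compounds shown alone.

For the measured compounds named here, only two compounds of this small series have entries so far in an ADME assay on J774.A1 cells (Mus musculus) for inhibition, read by MTT assay, with a stated time of 72 h (a higher number here means that more compound is needed for the effect, a lower number that less compound is needed), and neither gives a usable number. For compound 1 `Cc1ccccc1-c1nc(NCc2ccccc2)nc2ccccc12` the entry reads "not determined" (no result reported), so it provides no result. Compound 2 `CC(C)Nc1nc(NC2CC2)nc2ccccc12` gives > 40000 nM, which is a limit of the assay and not a number. This leaves the record with the limit of > 40000 nM in this assay, at which 1 of the 2 values shown sits. Going by the values given here, no step between two measured compounds is available as a guide.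

Compound 3 `CC(C)Nc1nc(NCc2ccccc2)nc2ccccc12` differs from compound 2 in one place, with benzyl in place of cyclopropyl on a nitrogen on an aromatic ring. With only a limit as a starting point, any forecast is loose. A moderate step toward a lower concentration is expected in this assay, probably beyond the usual scatter, although the reading may also remain a limit. The estimated change runs an at least 2.6-fold lower number from compound 2 to compound 3 (0.42 log units; beyond the scatter). Compound 3 is estimated at 15000 nM, with an expected range from 5000 nM to 40000 nM.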

Compound 3, half-maximal effective concentration: 7200 nM
Compound 3: middle estimate off by 2.1-fold (0.32 log units), on the high side; the range from low to high includes it.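

In this assay, this nitrogen position turns out to respond to the group it carries: benzyl in place of cyclopropyl gives an at least 5.5-fold lower number from compound 2 to compound 3 (0.74 log units; beyond the scatter). For the compounds shown here, until now, the only reading was that of compound 2 at > 40000 nM, a limit of the assay and not a number, so it was unclear whether any compound would give a measurable concentration. From the compounds shown here alone, the true size of the change remains unknown because one end of the step is that limit: the limit of > 40000 nM in this assay, at which 1 of the 3 values shown sits.

With only cyclopropyl and benzyl compared at this position, the pair cannot separate the effect of the aromatic ring from that of the larger group, and a cyclohexyl ring, a phenethyl chain or a benzyl group carrying a methoxy substituent could each test a different part of that question. Going by these compounds alone, compound 1 also has a benzyl group on its amine nitrogen, but with no result reported, no step to it can be read, and what the isopropyl group on the other amine nitrogen contributes stays open.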